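The source may hold more compounds than are shown below. What is called first, only, known or untested is meant among the compounds shown, and "the series" means these compounds.

Measured so far:
compound 1 `O=C1OC(Cc2nc(-c3ccc(Oc4ccccc4)cc3)no2)c2ccccc21` — > 40000 nM
compound 2 `CCC(C)Oc1ccc(C(O)C2OC(=O)c3c(OC)cc(OC)cc32)cc1` — > 40000 nM

Both readings come from an ADME assay on RAW264.7 cells (Mus musculus) for cytotoxicity, read by MTT assay, with a stated time of 24 h, in the absence of a further agent; on this read-out higher numbers stand for weaker inhibition and lower numbers for stronger inhibition. For compound 1 the result is a limit of the assay, > 40000 nM, not a number. For compound 2 likewise only a limit is reported, > 40000 nM. Among the compounds with values here, compound 2 therefore stands at the limit shared by every value shown so far, as the limit of > 40000 nM in this assay, at which 2 of the 2 values shown sit, records, and no step between measured compounds can be read from two limits.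

Compound 3 `COc1cc(OC)c2c(c1)C(C(O)c1ccc(OCc3ccc(Cl)cc3)cc1)OC2=O` has not yet been measured. It differs from compound 2 in one place: 4-chlorobenzyl in place of sec-butyl on an oxygen on an aromatic ring. Within the data shown here, no measured step in this assay informs this change, so the expected step that the limit leaves unreadable from compound 2 to compound 3 is none beyond the scatter. For compound 3 the estimate in this assay is 60000 nM, with an expected range of 30000 nM to 200000 nM, most likely reported again as a limit rather than a number.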

Compound 3, half-maximal inhibitory concentration: > 40000 nM
Compound 3 was reported as a limit; the forecaster's own chance of this, stated with the estimate: 85%; the middle value is on the limit's open side.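

In this assay compound 3 gives > 40000 nM, a limit and not a number. Within the data shown here, compound 2 also stands at a limit, so no step between compound 2 and compound 3 can be read. The compounds shown leave open whether any change to this series gives a number rather than a limit in this assay.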